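Iodo for fluoro beside a nitro group

The source may hold more compounds than are shown below. What is called first, only, known or untested is meant among the compounds shown, and "the series" means these compounds.

Compound 1 `Cc1cccc(C#Cc2cc(F)cc(C#N)c2)n1`: 1.22 nM
Compound 2 `Cc1cccc(C#Cc2cc(I)cc(C#N)c2)n1`: 0.71 nM
Compound 3 `O=[N+]([O-])c1cc(F)cc(C#Cc2ccccn2)c1`: 0.66 nM

Of the compounds shown here, three have been measured in a functional assay on HEK293 cells for antagonist activity at metabotropic glutamate receptor 5 (Rattus norvegicus), read by calcium flux; on this read-out higher numbers stand for weaker inhibition and lower numbers for stronger inhibition. Compound 1 gives 1.22 nM, compound 2 gives 0.71 nM and compound 3 gives 0.66 nM; all three lie within the scatter of one another, so no order among them is claimed.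

Compound 2 differs from compound 1 by iodo in place of fluoro on an aromatic carbon, and this change made a step of a 1.7-fold lower number from compound 1 to compound 2 (0.24 log units; within the scatter).

Compound 4 `O=[N+]([O-])c1cc(I)cc(C#Cc2ccccn2)c1` is not yet measured. It differs from compound 3 by iodo in place of fluoro on an aromatic carbon, the same kind of change, but the surroundings are not the same: in compound 1 the place is meta to a cyano group (2 heavy atoms) and meta to a group of 9 heavy atoms, whereas in compound 3 it is meta to a group of 8 heavy atoms and meta to a nitro group (3 heavy atoms). The difference between the two cores is not broken down here.

For compound 4 in this assay a step of about a 1.5-fold lower number from compound 3 to compound 4 (0.17 log units; within the scatter) is expected, resting on the measured step of a 1.7-fold lower number from compound 1 to compound 2 (0.24 log units; within the scatter) and on compound 3 with 0.66 nM. Compound 4 is thus estimated at 0.45 nM, between 0.2 nM and 1 nM.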

Compound 4, half-maximal inhibitory concentration: 2.09 nM
Compound 4: the middle estimate sits 4.6-fold (0.67 log units) below what was measured; the measured number lies above the stated range.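

In this assay, iodo in place of fluoro on the core of compound 3 gave a 3.2-fold higher number from compound 3 to compound 4 (0.50 log units; beyond the scatter), a weakening of inhibition beyond the scatter, so a step measured on the core of compound 1 cannot be taken over unchanged to this core. This does not show which difference between the two cores sets the steps apart, as the cores differ in more than one place, and each step rests on a single pair of compounds, with the earlier one within the scatter by itself. What can be said is that the same change behaved differently on the two cores: the same change on two cores in this assay, a 1.7-fold lower number (0.24 log units; within the scatter) from compound 1 to compound 2 and a 3.2-fold higher number (0.50 log units; beyond the scatter) from compound 3 to compound 4, 5.4-fold (0.74 log units) apart, beyond the scatter of two such steps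

The compounds shown leave open whether chloro or bromo on the same aromatic carbon would follow the step on the core of compound 1 or the step on the core of compound 3. They also leave open how the iodo for fluoro change would behave with an amine or a methoxy group in place of the nitro group.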